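A few compounds are considered here, and "the series" means these few. Any claim that something is new, unique, unknown or untested is made for them only; others in the source may bear on it.

Measured compounds:
compound 1 `O=c1c(SC(=S)N2CCCC2)coc2ccc(Cl)cc12`: > 25000 nM
compound 2 `O=c1c(SC(=S)N2CCCCC2)coc2ccccc12`: 16300 nM

In a functional assay on SW480 cells (Homo sapiens) for antiproliferative activity, read by MTT assay, with a stated time of 72 h (a higher number here means a weaker inhibitor, a lower number a stronger inhibitor), compound 1 reaches only a limit, > 25000 nM. In this assay, among the compounds with values here, compound 2 gives 16300 nM, the only number in hand. Within the data shown here, the one other value, that of compound 1, is a limit (the limit of > 25000 nM in this assay, at which 1 of the 2 values shown sits). Compound 3 `O=c1c(SC(=S)N2CCCCC2)coc2ccc(Cl)cc12` is not yet measured. Going from compound 2 to compound 3, (chloro in place of hydrogen on an aromatic carbon). Among the measured compounds shown here, no measured step of this kind exists. The step of a 1.2-fold higher number from compound 2 to compound 3 (0.09 log units; within the scatter) in this assay is expected to be small and, if beyond the scatter at all, toward weaker inhibition, because compound 1 sits at the limit (the limit of > 25000 nM in this assay, at which 1 of the 2 values shown sits). Compound 3 is therefore expected near 20000 nM, within 9000 nM to 45000 nM.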

Compound 3, half-maximal inhibitory concentration: > 25000 nM
Compound 3 gave a limit, no number; the forecaster's own chance of this, stated with the estimate: 40%; at least 1.2-fold (0.09 log units) between middle value and limit.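

In this assay chloro in place of hydrogen on an aromatic carbon now has its first step, an at least 1.5-fold higher number from compound 2 to compound 3 (0.18 log units; that floor lies within the scatter) and this floor leaves the true size open. On the piperidin-1-yl compounds, chloro gives no sign of stronger inhibition. The change from pyrrolidin-1-yl to piperidin-1-yl among the chloro compounds cannot be read, as both values are limits: the limit of > 25000 nM in this assay, at which 2 of the 3 values shown sit.

On these data alone, whether fluoro or methoxy on the same aromatic carbon would bring a number back within range stays open. So does the effect of morpholin-4-yl on the thiocarbonyl carbon.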